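Acetoxy to methoxy: an estimate for compound 4

The compounds below may be only part of what the source reports. "The series", "measured", "known", "first", "only" and "open" are said of these compounds alone.

Three compounds have values so far in a functional assay on MCF7 cells (Homo sapiens) for cytotoxicity, read by XTT assay, with a stated time of 24 h (a lower number here means a stronger inhibitor, a higher number a weaker inhibitor), as follows
- compound 1 `Cc1cc(Cl)c2c(c1O)C(=O)C=CC2=O` gives 10000 nM
- compound 2 `COc1c(C)cc(Cl)c2c1C(=O)C=CC2=O` gives 16200 nM
- compound 3 `CC(=O)Oc1cc(C)c(Cl)c2c1C(=O)C=CC2=O` gives 37900 nM

Compound 3 has the highest number of the three and is the weakest inhibitor here. Its gaps to compound 2 and to compound 1 both lie beyond the scatter. Compound 4 `COc1cc(C)c(Cl)c2c1C(=O)C=CC2=O` has not yet been measured. It differs from compound 3 by methyl in place of acetyl on an oxygen on an aromatic ring in a change from acetoxy to methoxy, with methyl in place of acetyl on an oxygen on an aromatic ring.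

Within the data shown here, no measured step makes this exact exchange. Among the measured compounds shown here, the nearest one is a 1.6-fold higher number from compound 1 to compound 2 (0.21 log units; within the scatter) and it concerns methyl in place of hydrogen, so it shows only that a methoxy compound can sit close to its hydroxy partner. For the measured compounds named here, compound 2, the only measured methoxy compound, gives 16200 nM but differs from compound 3 elsewhere as well, so the comparison is indirect. On that basis a modest fall in the number is expected, and the estimated change is a 1.9-fold lower number from compound 3 to compound 4 (0.28 log units; within the scatter) in this assay for this exchange. Compound 4 is estimated at 20000 nM with an expected range from 8000 nM to 45000 nM before any measurement.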

Compound 4, half-maximal inhibitory concentration: 20600 nM
Compound 4: the middle estimate sits 1.0-fold (0.01 log units) below what was measured, and the stated range covers the measured number.
By their numbers in this assay, from the lowest: compounds 1, 2, 4 and 3 (each within the scatter of the next, the first and the last beyond it).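

Among these compounds, putting methyl in place of acetyl on an oxygen on an aromatic ring gives a 1.8-fold lower number from compound 3 to compound 4 (0.26 log units; within the scatter) in this assay and is the first direct reading of this exchange. At this place, then, the assay does not separate the acetoxy compound from the methoxy compound, even though the acetyl that leaves brings a double bond and a hydrogen-bond acceptor that the entering methyl lacks. The earlier step of a 1.6-fold higher number from compound 1 to compound 2 (0.21 log units; within the scatter) concerned only methyl in place of hydrogen, so it could say nothing about acetyl, and the two exchanges on such an oxygen now both stand within the scatter.

The compounds shown leave open whether a bulkier group on this oxygen, such as a benzoyl or a longer alkyl chain, would give a step beyond the scatter. They also leave open what an amine or a carboxylic acid at this place would do, and whether the free hydroxy form of the core of compound 4 would stand apart from its methoxy partner.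

No measurement available here offers an explanation for this result.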